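Ethyl to isopropyl: expected unbound fraction of compound 3

The compounds below may be only part of what the source reports. "The series", "measured", "known", "first", "only" and "open" are said of these compounds alone.

- Compound 1 (`CCNC(=O)Nc1nc2cc(-c3ccc(F)nc3)c(=O)n(C)c2s1`) reads ("not determined" (no result reported))
- Compound 2 (`CCNC(=O)Nc1nc2cc(-c3cccnc3)c(=O)n(CC)c2s1`) reads (0.11)

Both entries come from an ADME assay on a cell-free system (plasma, Homo sapiens) (a lower number here means a smaller unbound share, a higher number a larger unbound share of the compound), and only one of them carries a number. Compound 2 at (0.11) therefore has nothing to be ranked against, and it cannot be called high or low within this series. Compound 1 offers no result for comparison.

Compound 3 (`CCNC(=O)Nc1nc2cc(-c3cccnc3)c(=O)n(C(C)C)c2s1`) shares the core of compound 2 and differs by one change (methyl in place of hydrogen on a saturated chain carbon bound to an aromatic nitrogen and a saturated chain carbon). This is methyl in place of hydrogen on a saturated chain carbon bound to an aromatic nitrogen and a saturated chain carbon, or ethyl to isopropyl when cut one bond further out.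

Among the measured compounds shown here, no measured pair shows what such a change does in this assay, so the expectation rests on compound 2 at (0.11) alone. A small move toward a smaller unbound share is expected, though none beyond the scatter would be no surprise. The expected shift is (a 1.4-fold lower number from compound 2 to compound 3 (0.14 log units; within the scatter)) and remains an estimate within the scatter. For compound 3 the estimated unbound fraction is (0.08), with an expected range from (0.045) to (0.14) in repeat measurements.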

Compound 3, unbound fraction: 0.21
Estimate against measurement, compound 3: 2.6-fold (0.42 log units) below; measured number outside the range, above it.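

In this assay, among the compounds shown here, the pair gives the first reading of methyl in place of hydrogen on a saturated chain carbon bound to an aromatic nitrogen and a saturated chain carbon, ethyl to isopropyl when cut one bond further out: a 1.9-fold higher number from compound 2 to compound 3 (0.28 log units; within the scatter). As that step lies within the scatter, compound 2 and compound 3 cannot be told apart in this read-out, and this single pair shows no effect of the added methyl at this place in either direction. No available evidence bears on this result.

One pair within the scatter leaves open whether any change at this place can move the unbound fraction beyond the scatter, for example a longer chain such as butyl, a chain ending in an amine or a chain ending in a carboxylic acid. Going by these compounds, compound 1, at "not determined" (no result reported), offers no number to compare, so the shared core has only these two readings and the effect of changes elsewhere on it remains open.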